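A Methyl Removed Twice, on Two Different Cores

This account rests on a few compounds, and the source may have more. Where it says the series, first, only, none or still open, it means among the compounds named here.

Of the compounds shown here, three have been measured in a functional assay on the whole organism (Tail, strain ICR) with Mus musculus as the target, in the tail flick test, with a stated time of 120 min, at a dose of 25 umol/kg by the oral route; on this read-out higher numbers stand for a stronger effect at the one dose given and lower numbers for a weaker effect. Compound 1, `C[C@H](NC(=O)CN(c1nc(Cl)nc2[nH]cnc12)C1CC1)C(=O)OCc1ccccc1`, gives 36.1% in this assay. Compound 2, `O=C(CN(c1nc(Cl)nc2[nH]cnc12)C1CC1)NCC(=O)OCc1ccccc1`, gives 21.7% in this assay. The two differ by a single change, (hydrogen in place of methyl on a saturated chain carbon bound to an amide-type nitrogen and a carbonyl carbon), and the step of a number 14.4 percentage points lower from compound 1 to compound 2 (beyond the scatter) shows the methyl to have counted for a meaningful part of the response in this setting.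

Compound 3, `C[C@@H](O)[C@H](NC(=O)CN(c1ncnc2c1ncn2C1CCCCO1)C1CC1)C(=O)OCc1ccccc1`, gives 10.9% in this assay, the lowest of the three numbers. The difference between its core and the core of compound 1 is not broken down here.

Compound 4, `O=C(CN(c1ncnc2c1ncn2C1CCCCO1)C1CC1)N[C@@H](CO)C(=O)OCc1ccccc1`, has not yet been measured. It differs from compound 3 by hydrogen in place of methyl on a saturated chain carbon bound to an oxygen on a saturated carbon and a saturated chain carbon. Among the compounds with values here, this is the same kind of change as the one from compound 1 to compound 2, but not the same: there the place was a saturated chain carbon bound to an amide-type nitrogen and a carbonyl carbon, here it is a saturated chain carbon bound to an oxygen on a saturated carbon and a saturated chain carbon, and the cores carrying the change differ as well.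

Within the data shown here, the expected step, a number 4.9 percentage points lower from compound 3 to compound 4 (within the scatter), rests on the one precedent, a number 14.4 percentage points lower from compound 1 to compound 2 (beyond the scatter), tempered because compound 3 already starts from 10.9%, leaving little room to fall. Compound 4 is therefore expected to give 6% in this assay, with a range from -4% to 17%.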

Compound 4, a percentage reported as activity, at one dose (the size of the read-out at that dose, not a potency): 29.2%
Beside the measured number, compound 4's estimate is 23.2 percentage points below it, outside the stated range (above it).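

In this assay, taking away the methyl on the side chain gave a number 18.3 percentage points higher from compound 3 to compound 4 (beyond the scatter), so compound 4 rises where the same kind of change on the other core fell. Set side by side, the two steps run in opposite directions, and in this series the direction of the change did not carry from one core to the other: the same change on two cores in this assay, a number 14.4 percentage points lower (beyond the scatter) from compound 1 to compound 2 and a number 18.3 percentage points higher (beyond the scatter) from compound 3 to compound 4, 32.7 percentage points apart, beyond the scatter of two such steps

What this does not show is why the direction differs. The two changes sit at different places, one on a saturated chain carbon bound to an amide-type nitrogen and a carbonyl carbon, the other on a saturated chain carbon bound to an oxygen on a saturated carbon and a saturated chain carbon, and the cores differ as well, leaving the two pairs unable to separate the part played by the core from that of the place, and each step rests on a single read-out at one dose and one time.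

The compounds shown leave open how the 1-hydroxyethyl and hydroxymethyl chains would behave on the core of compound 1. They also leave open whether a longer chain or an amine at that place on the core of compound 4 would keep or lose the response.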